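From 4-methylphenyl to 4-methoxyphenyl: notes on the series

The source may hold more compounds than are shown below. What is called first, only, known or untested is meant among the compounds shown, and "the series" means these compounds.

Among the measured compounds shown here, in a functional assay on THP-1 cells (Homo sapiens) (a higher number here means a weaker inhibitor, a lower number a stronger inhibitor), compound 2 (`CCSC[C@@](O)([C@@H](Nc1cccc2nc(C)ccc12)c1ccc(C)cc1)C(F)(F)F`) gives 2.51 nM, the lower of the two numbers so far and beyond the scatter from compound 1 (`CC[C@H]1c2c(cc(F)c(F)c2O)[C@H](Nc2cccc3[nH]c(=O)ccc23)[C@@](O)(C(F)(F)F)C1OC`), which gives 6.31 nM. Compound 3 (`CCSC[C@@](O)([C@@H](Nc1cccc2nc(C)ccc12)c1ccc(OC)cc1)C(F)(F)F`) carries methoxy in place of methyl on an aromatic carbon, para to a large group: methoxy in place of methyl on an aromatic carbon. For the measured compounds named here, no measured pair shows this change, so the expectation rests only on compound 2 at 2.51 nM: a small move towards a higher number in this assay, possibly none beyond the scatter. The expected step runs a 1.3-fold higher number from compound 2 to compound 3 (0.11 log units; within the scatter). For compound 3 the estimated value is 3.2 nM, with an expected range of 1 nM to 10 nM.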

Compound 3, half-maximal inhibitory concentration: 6.31 nM
The estimate for compound 3 lay 2.0-fold (0.29 log units) below the measured number; measured number inside the range.
By their numbers in this assay, from the lowest: compound 2; then compounds 1 and 3 (each within the scatter of the next).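

Para to a large group on the aromatic ring, methoxy in place of methyl gives the only step that can be read at this position: a 2.5-fold higher number from compound 2 to compound 3 (0.40 log units; beyond the scatter) in this assay. The position is thus not indifferent to this change, and 4-methylphenyl gives the lower number of the pair. Nothing available explains the step.

From the compounds shown here alone, only these two groups stand at this position, so how an ethyl group, a hydroxyl group or a chlorine atom would read there remains open. Going by these compounds, whether the same step holds on the core of compound 1 is also open.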